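Ring Opening of the Carboxycyclopropyl Group in Two Series

The source may report more compounds than this note shows. Statements on the series, on what has been measured and on what is new or still open speak of the compounds shown alone.

Measured compounds:
compound 1, `O=C(O)C1CC1c1ccc(NCc2cccc(Oc3ccccc3)c2)cc1`, in a functional assay for agonist activity at Free fatty acid receptor 1 (Homo sapiens) (on this read-out lower numbers stand for an effect already at smaller amounts and higher numbers for an effect only at larger amounts of compound), compound 1 gives 50.1 nM
compound 2, `O=C(O)CCCc1ccc(NCc2cccc(Oc3ccccc3)c2)cc1`, compound 2 gives 3160 nM
compound 3, `O=C(O)C1CC1c1ccc(NCc2ccc(-c3ccccc3)cc2)cc1`, compound 3 gives 39.8 nM

Compound 1 and compound 2 share one core and differ in a single place, (3-carboxypropyl in place of 2-carboxycyclopropyl on an aromatic carbon). This change made a large step, a 63-fold higher number from compound 1 to compound 2 (1.80 log units; beyond the scatter). Compound 3 carries a different core; the difference between the two cores is not broken down here. Its value and that of compound 1 lie within the usual scatter of each other, so no order between them is claimed.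

Compound 4, `O=C(O)CCCc1ccc(NCc2ccc(-c3ccccc3)cc2)cc1`, is not yet measured. It differs from compound 3 by 3-carboxypropyl in place of 2-carboxycyclopropyl on an aromatic carbon, the same change at the same place as between compound 1 and compound 2. Because the earlier step was a 63-fold higher number from compound 1 to compound 2 (1.80 log units; beyond the scatter), a step of similar size is expected here, a 63-fold higher number from compound 3 to compound 4 (1.80 log units; beyond the scatter). Among the measured compounds shown here, only one example of the change is known, so this expectation rests on a single pair. For compound 4 the estimated value is 2500 nM, with a range from 700 nM to 9000 nM.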

Compound 4, half-maximal effective concentration: 1580 nM
Compound 4: the middle estimate sits 1.6-fold (0.20 log units) above what was measured; measured number inside the range.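

In this assay, putting 3-carboxypropyl in place of 2-carboxycyclopropyl on the second core again gave a large step, a 40-fold higher number from compound 3 to compound 4 (1.60 log units; beyond the scatter). Set beside the earlier step, the change carried from one core to the other with no difference in size that stands out from the scatter: the same change on two cores in this assay, a 63-fold higher number (1.80 log units; beyond the scatter) from compound 1 to compound 2 and a 40-fold higher number (1.60 log units; beyond the scatter) from compound 3 to compound 4, 1.6-fold (0.20 log units) apart, within the scatter of two such steps. This shows that the step held on these two cores in this one read-out, but two pairs set no rule for other cores in the series, and they do not show why the 3-carboxypropyl compounds give the higher numbers.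

The compounds shown leave open whether a 2-carboxycyclobutyl group, or a tetrazole in place of the carboxylic acid, would give numbers closer to those of the 2-carboxycyclopropyl compounds or to those of the 3-carboxypropyl compounds. On these data alone, it also remains open whether the step would keep its size if an ether oxygen took the place of the amine nitrogen in these cores.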